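The source may hold more compounds than are shown below. What is called first, only, known or untested is meant among the compounds shown, and "the series" means these compounds.

Of the compounds shown here, three have been measured in an assay on brain (strain C57BL6) for displacement of a labelled ligand from AP2-associated protein kinase 1 (Mus musculus), read by scintillation counting, with a stated time of 1 h; on this read-out lower numbers stand for stronger inhibition and higher numbers for weaker inhibition. Compound 3 `CC(=O)Nc1cc(-c2ccc(OC[C@@H](N)CC(C)C)c(Cl)c2)ccn1` gives 0.06 nM, compound 1 `CC(=O)Nc1cc(-c2ccc(OC[C@@H](N)CC(C)C)c(C)c2)ccn1` gives 0.08 nM, and compound 2 `COC(=O)Nc1cc(-c2cc(Cl)c(OC[C@@](C)(N)CC(C)C)cn2)ccn1` gives 0.11 nM. Compound 1 arises from compound 3 by methyl in place of chloro on an aromatic carbon, and that step was a 1.3-fold higher number from compound 3 to compound 1 (0.12 log units; within the scatter). Compound 4 `COC(=O)Nc1cc(-c2cc(C)c(OC[C@@](C)(N)CC(C)C)cn2)ccn1` is not yet measured; it arises from compound 2 by methyl in place of chloro on an aromatic carbon. The difference between the cores of compound 2 and compound 3 is not broken down here. The two changes are the same kind of change, not the same: in compound 3 the place is on a six-membered aromatic ring of carbon only, ortho to a (2-amino-4-methylpentyl)oxy group, whereas in compound 2 it is on a ring with 1 nitrogen, ortho to a (2-amino-2,4-dimethylpentyl)oxy group and opposite the ring nitrogen. The expectation rests on the earlier step of a 1.3-fold higher number from compound 3 to compound 1 (0.12 log units; within the scatter), which lay within the scatter. Compound 4 is therefore expected to show a step of a 1.3-fold higher number from compound 2 to compound 4 (0.10 log units; within the scatter) in this assay. Compound 4 is estimated at 0.14 nM, with a range from 0.06 nM to 0.35 nM.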

Compound 4, inhibition constant: 1.4 nM
Estimate against measurement, compound 4: 10-fold (1.00 log units) below; the whole stated range lies below it.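

In this assay, methyl in place of chloro on the core of compound 2 gave a 13-fold higher number from compound 2 to compound 4 (1.10 log units; beyond the scatter). Set beside the earlier step, the same change does not carry over unchanged between these two cores: the same change on two cores in this assay, a 1.3-fold higher number (0.12 log units; within the scatter) from compound 3 to compound 1 and a 13-fold higher number (1.10 log units; beyond the scatter) from compound 2 to compound 4, 9.5-fold (0.98 log units) apart, beyond the scatter of two such steps This shows that a step read on one core cannot be assumed on the other, but not which difference between the cores matters, and two pairs cannot show how widely this holds in the series.

The cores differ in more than one place, including the ring nitrogen and the (2-amino-2,4-dimethylpentyl)oxy group in place of the (2-amino-4-methylpentyl)oxy group, and the compounds shown do not separate these. Also open, as far as these compounds go, is how a fluoro or a methoxy group in the same place would behave on either core.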